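Compound 1 to Compound 4: a Methyl Group Shifted

A few compounds are considered here, and "the series" means these few. Any claim that something is new, unique, unknown or untested is made for them only; others in the source may bear on it.

Compound 1 `CC1=CC[C@H](C(C)C)c2cc(C)c(OC(=O)c3cccc(C)c3)cc21` was tested in a functional assay on MCF7 cells (Homo sapiens) for antiproliferative activity, read by sulforhodamine B assay, with a stated time of 48 h, tested at 50 uM (a higher number here means more inhibition at the concentration tested (going by the name of the read-out), a lower number less inhibition), where compound 1 gives 54.9%. Among the three measured numbers this is the second highest: compound 2 `Cc1cc2c(C(C)C)ccc(C)c2cc1OC(=O)c1ccc([N+](=O)[O-])cc1` gives 100% in this assay, and compound 3 `COc1cccc(C(=O)Oc2cc3c(C)ccc(C(C)C)c3cc2C)c1` gives 31.8%, so compound 1 lies clearly above compound 3 and clearly below compound 2, both gaps beyond the scatter.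

Going by the values given here, the only measured step that differs in one place is a number 68.2 percentage points lower from compound 2 to compound 3 (beyond the scatter), a large change brought about by 3-methoxyphenyl in place of 4-nitrophenyl on a carbonyl carbon. It involves a core different from that of compound 1 and a different kind of substituent exchange, so it does not bear on the step at hand.

Compound 4 `CC1=CC[C@H](C(C)C)c2cc(C)c(OC(=O)c3ccc(C)cc3)cc21` differs from compound 1 by 4-methylphenyl in place of 3-methylphenyl on a carbonyl carbon. Among the compounds with values here, no measured pair shows what shifting a methyl group on this ring does. With nothing pointing either way, compound 4 is expected to stay within the scatter of compound 1, a step of a number 0.1 percentage points higher from compound 1 to compound 4 (within the scatter). The estimate for compound 4 is 55%, with a range from 30% to 80%.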

Compound 4, a percentage reported as inhibition, at one concentration (the size of the read-out at that concentration, not a potency): 65%
Compound 4: middle estimate off by 10 percentage points, on the low side; the measured number falls inside the stated range.
By their numbers in this assay, from the lowest: compound 3; then compound 1; then compound 4; then compound 2.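

Going by these compounds alone, the step of a number 10.1 percentage points higher from compound 1 to compound 4 (beyond the scatter) is the first measured on the core of compound 1, and it shows that this assay responds to where the methyl group sits on this ring. The two compounds have the same atoms joined differently, so the modest change comes from moving the methyl group alone, with no group gained or lost. Nothing available explains this change.

On these data alone, it remains open whether the higher number would hold if the methyl group of 4-methylphenyl gave way to an amine, a carboxylic acid or a longer chain such as butyl. Also open, as far as these compounds go, is how 4-nitrophenyl, present in compound 2, would behave on the core of compound 1.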